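From 2,5-difluorophenyl to 2,6-difluorophenyl in a narrow series

This account rests on a few compounds, and the source may have more. Where it says the series, first, only, none or still open, it means among the compounds named here.

- compound 1 `CC(C)[C@H](NC(=O)COc1cccc2ccccc12)C(=O)N[C@@H](CC(=O)O)C(=O)COc1ccccc1C(F)(F)F`: 17300 nM
- compound 2 `CC(C)[C@H](NC(=O)COc1cccc2ccccc12)C(=O)N[C@@H](CC(=O)O)C(=O)COc1ccccc1[N+](=O)[O-]`: 27700 nM
- compound 3 `CC(C)[C@H](NC(=O)COc1cccc2ccccc12)C(=O)N[C@@H](CC(=O)O)C(=O)COc1cc(F)ccc1F`: 19700 nM

All three values come from a functional assay with Homo sapiens as the target; on this read-out higher numbers stand for weaker inhibition and lower numbers for stronger inhibition. The value of compound 3 lies within the scatter of the values of compound 1 and compound 2.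

The next compound, compound 4 `CC(C)[C@H](NC(=O)COc1cccc2ccccc12)C(=O)N[C@@H](CC(=O)O)C(=O)COc1c(F)cccc1F`, keeps everything in compound 3 except one group: 2,6-difluorophenyl in place of 2,5-difluorophenyl on an oxygen on a saturated carbon. Put simply, 2,6-difluorophenyl stands in place of 2,5-difluorophenyl on an oxygen on a saturated carbon. Within the data shown here, no measured pair makes exactly this change, so the closest guides are the exchanges at the same place. These gave a 1.6-fold higher number from compound 1 to compound 2 (0.20 log units; within the scatter), a 1.1-fold higher number from compound 1 to compound 3 (0.06 log units; within the scatter) and a 1.4-fold lower number from compound 2 to compound 3 (0.15 log units; within the scatter). With only these three compounds to go on, no step beyond the scatter is expected in this assay, in either direction. The expected step is a 1.0-fold higher number from compound 3 to compound 4 (0.01 log units; within the scatter). The estimate for compound 4 is 20000 nM, with an expected range from 10000 nM to 38000 nM.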

Compound 4, half-maximal inhibitory concentration: > 100000 nM
Compound 4: a limit, no number; the forecaster's own chance of this, stated with the estimate: 5%; middle value at least 5.0-fold (0.69 log units) away from the limit.
By their numbers in this assay, from the lowest: compounds 1, 3 and 2 (each within the scatter of the next). At a limit, above all of these: compound 4.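

In this assay, compound 4 carries a limit of the assay and not a number: the limit of > 100000 nM in this assay, at which 1 of the 4 values shown sits.

The exchanges among the first three compounds all stayed within the scatter, but rearranging the same atoms in the aryl group gives an at least 5.0-fold higher number from compound 3 to compound 4 (0.70 log units; beyond the scatter), and the gaps to the other two compounds are also beyond the scatter: an at least 3.6-fold higher number from compound 2 to compound 4 (0.55 log units; beyond the scatter) and an at least 5.7-fold higher number from compound 1 to compound 4 (0.76 log units; beyond the scatter). This position on the oxygen is therefore sensitive to more than the atoms present, since 2,5-difluorophenyl and 2,6-difluorophenyl have identical counts and yet give clearly different results.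

From the compounds shown here alone, it remains open whether chlorine or methyl in place of the two fluorines of 2,6-difluorophenyl would give the same result. A plain phenyl on the same oxygen would also be needed to show how much either fluorine contributes.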